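This account rests on a few compounds, and the source may have more. Where it says the series, first, only, none or still open, it means among the compounds named here.

Measured so far in a functional assay on MCF7 cells (Homo sapiens) for antiproliferative activity, read by MTT assay, with a stated time of 72 h; a lower number here means a stronger inhibitor, a higher number a weaker inhibitor:
- compound 1 `CCN1CCN(c2cc(C)c3cc(NC(=O)c4cccc(Cl)c4)ccc3n2)CC1`: 3820 nM
- compound 2 `Cc1cc(N(C)C)nc2ccc(NC(=O)c3ccc(Cl)c(Cl)c3)cc12`: 33300 nM
- compound 3 `Cc1cc(N2CCN(C(C)C)CC2)nc2ccc(NC(=O)c3ccc(Cl)c(Cl)c3)cc12`: 1710 nM

Compound 1 stands in the middle of these three numbers, with compound 3 lower and compound 2 higher. The next compound is compound 4 `CCN1CCN(c2cc(C)c3cc(NC(=O)c4ccc(Cl)cc4)ccc3n2)CC1`, which has the same atoms as compound 1 joined differently: 4-chlorophenyl in place of 3-chlorophenyl on a carbonyl carbon. In words, 4-chlorophenyl stands in place of 3-chlorophenyl on a carbonyl carbon.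

For the measured compounds named here, only one single-site step has been measured in this assay. That step, a 19-fold lower number from compound 2 to compound 3 (1.29 log units; beyond the scatter), is large, but it puts 4-isopropylpiperazin-1-yl in place of dimethylamino and leaves the group on the carbonyl carbon untouched. Going by the values given here, it therefore gives no direct guide to this change, and no measured pair tests the chlorophenyl swap alone. No step beyond the scatter is expected in this assay, and neither direction is favoured. The expected step is a 1.1-fold lower number from compound 1 to compound 4 (0.04 log units; within the scatter). For compound 4 the estimated value is 3500 nM, with an expected range from 1500 nM to 8000 nM.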

Compound 4, half-maximal inhibitory concentration: 1530 nM
Beside the measured number, compound 4's estimate is 2.3-fold (0.36 log units) above it; the measured number falls inside the stated range.
By their numbers in this assay, from the lowest: compounds 4 and 3 (each within the scatter of the next); then compound 1; then compound 2.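

In this assay, 4-chlorophenyl in place of 3-chlorophenyl on the carbonyl carbon gives a 2.5-fold lower number from compound 1 to compound 4 (0.40 log units; beyond the scatter), the first step measured at this place in the series. Compound 1 and compound 4 have the same atoms and differ only in the chlorophenyl group, so the way that group is joined can alone shift the number beyond the scatter, although this step is modest and the earlier 19-fold lower number from compound 2 to compound 3 (1.29 log units; beyond the scatter) at the other end of the molecule is large. Nothing measured here accounts for the step.

As far as these compounds go, it remains open whether the same swap gives a step of like size and direction with 4-isopropylpiperazin-1-yl or dimethylamino on the shared core. Also open, from the compounds shown here alone, is how a plain phenyl or a 4-methoxyphenyl on the carbonyl carbon would compare with 4-chlorophenyl.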